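The compounds below may be only part of what the source reports. "The series", "measured", "known", "first", "only" and "open" are said of these compounds alone.

Values so far in an ADME assay on the whole organism (Rattus norvegicus, strain Fischer 344) for pharmacokinetics, with a stated time of 8 h, at a dose of 3 mg/kg by the oral route; on this read-out lower numbers stand for lower exposure and higher numbers for higher exposure at the dose given
- compound 1 `Cc1cc(N2CCC[C@H](COCc3nc(C)no3)C2)c2c(N)c(C(N)=O)sc2n1` gives 722 ng.h/mL
- compound 2 `COC[C@H]1CCCN(c2ccnc3sc(C(N)=O)c(N)c23)C1` gives 227 ng.h/mL
- compound 3 `NC(=O)c1sc2nccc(N3CCC[C@H](COCCO)C3)c2c1N` gives 320 ng.h/mL

Compound 3 lies within the scatter of compound 2 and beyond the scatter below compound 1. Next is compound 4 `CCOCCOC[C@H]1CCCN(c2ccnc3sc(C(N)=O)c(N)c23)C1`, where the change is ethyl in place of hydrogen on an oxygen on a saturated carbon, turning 2-hydroxyethyl into 2-ethoxyethyl. Going by the values given here, one measured step bears on this chain, a 1.4-fold higher number from compound 2 to compound 3 (0.15 log units; within the scatter), and it stays within the scatter. Among the compounds with values here, no measured step covers the ethyl group itself, so the basis is thin. No shift beyond the scatter is expected in this assay, and the expected step is a 1.1-fold lower number from compound 3 to compound 4 (0.06 log units; within the scatter). For compound 4 the estimate is 280 ng.h/mL, with an expected range from 110 ng.h/mL to 700 ng.h/mL.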

Compound 4, area under the concentration-time curve: 2000 ng.h/mL
Beside the measured number, compound 4's estimate is 7.1-fold (0.85 log units) below it; the whole stated range lies below it.
By their numbers in this assay, from the lowest: compounds 2 and 3 (each within the scatter of the next); then compound 1; then compound 4.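

In this assay, going by these compounds alone, ethyl on the oxygen of the 2-hydroxyethyl chain gives the first step at this position that lies beyond the scatter, a 6.3-fold higher number from compound 3 to compound 4 (0.80 log units; beyond the scatter). The 2-ethoxyethyl chain also clears the scatter against the methoxymethyl compound, with an 8.8-fold higher number from compound 2 to compound 4 (0.95 log units; beyond the scatter), whereas the 2-hydroxyethyl chain gave only a 1.4-fold higher number from compound 2 to compound 3 (0.15 log units; within the scatter), so chain growth alone does not carry the rise in these compounds. Nothing shown accounts for the rise.

Open, from the compounds shown here alone, is whether a methyl group, a longer chain or an amine in place of the ethoxy group would keep this exposure. Also open, going by these compounds, is whether the ethyl effect holds on the core of compound 1.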